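Two Measured Compounds and One Expected Value

The source may hold more compounds than are shown below. What is called first, only, known or untested is meant among the compounds shown, and "the series" means these compounds.

Compound 1 `O=C(/C=C/c1ccc(Cl)cc1)c1cccc(NC(=O)c2cc(-c3ccncc3)n[nH]2)c1` gives 63900 nM in a functional assay, read by spectrophotometry, tested at 100 uM; a lower number here means a stronger inhibitor, a higher number a weaker inhibitor.
Compound 2 `CN(C)c1ccc(/C=C/C(=O)c2cccc(NC(=O)c3cc(-c4ccncc4)n[nH]3)c2)cc1` gives 41900 nM in this assay.

Among the measured compounds shown here, compound 2 holds the lowest of the two numbers, yet the only measured step, a 1.5-fold lower number from compound 1 to compound 2 (0.18 log units; within the scatter), lies within the scatter, so the two compounds cannot be ranked. Compound 3 `COc1cc(/C=C/C(=O)c2cccc(NC(=O)c3cc(-c4ccncc4)n[nH]3)c2)cc(OC)c1OC` differs from compound 2 by 3,4,5-trimethoxyphenyl in place of 4-(dimethylamino)phenyl on a double-bonded chain carbon bound to a double-bonded chain carbon. For the measured compounds named here, that step at the same place exchanged other groups and stayed within the scatter; no measured step bears directly on the entering group. No step beyond the scatter is therefore expected in this assay, and compound 3 is estimated at 45000 nM, ranging from 15000 nM to 140000 nM, an expected step of a 1.1-fold higher number from compound 2 to compound 3 (0.03 log units; within the scatter).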

Compound 3, half-maximal inhibitory concentration: 54500 nM
Compound 3: middle estimate off by 1.2-fold (0.08 log units), on the low side; the range from low to high includes it.
By their numbers in this assay, from the lowest: compounds 2, 3 and 1 (each within the scatter of the next).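

With 3,4,5-trimethoxyphenyl on this double-bonded chain carbon, this assay shows a 1.3-fold higher number from compound 2 to compound 3 (0.11 log units; within the scatter) and also a 1.2-fold lower number from compound 1 to compound 3 (0.07 log units; within the scatter). So a larger entering group, with 12 heavy atoms in place of 9 and oxygen instead of nitrogen or chlorine, still leaves the three compounds unranked. No measurement shown here offers an explanation for this result. On these data alone, whether a carboxylic acid or an open-chain amine in place of the aromatic ring at this chain carbon would give a step beyond the scatter remains open.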